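The source may report more compounds than this note shows. Statements on the series, on what has been measured and on what is new or still open speak of the compounds shown alone.

Measured compounds in a functional assay on HepG2 cells (Homo sapiens) for antiproliferative activity, read by MTT assay, with a stated time of 48 h; on this read-out higher numbers stand for weaker inhibition and lower numbers for stronger inhibition:

Compound 1 `O=c1cc(-c2ccccc2)oc2cc(O)c(OCCCN3CCCCC3)c(O)c12` — compound 1 gives 70600 nM
Compound 2 `O=c1cc(-c2ccccc2)oc2cc(OCc3ccccc3)c(OCCCN3CCCCC3)c(O)c12` — compound 2 gives 2200 nM
Compound 3 `COc1cc2oc(-c3ccccc3)cc(=O)c2c(O)c1OCCCN1CCN(C)CC1` — compound 3 gives 15100 nM

Compound 2 gives the lowest number of the three; the nearest of the others is compound 3, and the furthest is compound 1. Within the data shown here, the one single-point step among the measured compounds is the benzyl in place of hydrogen on an oxygen on an aromatic ring, which gave a 32-fold lower number from compound 1 to compound 2 (1.51 log units; beyond the scatter).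

Compound 4 `CN1CCN(CCCCOc2c(OCc3ccccc3)cc3oc(-c4ccccc4)cc(=O)c3c2O)CC1` is not yet measured. It differs from compound 2 by (4-methylpiperazin-1-yl)methyl in place of piperidin-1-yl on a saturated chain carbon, three bonds along the chain from an oxygen on an aromatic ring; seen one bond further out, this is 3-(piperidin-1-yl)propyl to 4-(4-methylpiperazin-1-yl)butyl. Among the measured compounds shown here, no measured step covers this change. Compound 3, which also carries the 4-methylpiperazin-1-yl group but differs from compound 2 in a second place as well, gives a higher number than compound 2, which offers only a loose hint. Compound 4 is therefore expected to show a moderate step upward, a 2.0-fold higher number from compound 2 to compound 4 (0.31 log units; beyond the scatter), with wide uncertainty. The estimated value of compound 4 in this assay is 4500 nM, within a range from 1200 nM to 16000 nM.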

Compound 4, half-maximal inhibitory concentration: 2500 nM
For compound 4 the middle estimate is 1.8-fold (0.26 log units) above the measured one, within the range that was stated.
By their numbers in this assay, from the lowest: compounds 2 and 4 (each within the scatter of the next); then compound 3; then compound 1.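

In this assay the change from 3-(piperidin-1-yl)propyl to 4-(4-methylpiperazin-1-yl)butyl gave a 1.1-fold higher number from compound 2 to compound 4 (0.06 log units; within the scatter), the first step read at this chain rather than on the oxygen that carries the benzyl group, where the earlier step was a 32-fold lower number from compound 1 to compound 2 (1.51 log units; beyond the scatter). With the benzyl group in place, this chain position therefore took the entering group, with 8 heavy atoms against 6 and a second nitrogen in its ring, without a difference that stands out from the scatter. No measurement at hand accounts for this result.

Ring and chain length changed together in this one step, so the contribution of each stays open; 3-(4-methylpiperazin-1-yl)propyl and 4-(piperidin-1-yl)butyl on the same core would separate them. On these data alone, how a morpholin-4-yl or a dimethylamino group at the chain end would read also remains open.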